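Shifting One Methoxy Group: From Compound 1 to Compound 4

The source may report more compounds than this note shows. Statements on the series, on what has been measured and on what is new or still open speak of the compounds shown alone.

Compound 1 `COc1ccc(OC)c(N2C(=O)CSC2c2cccc(C(=O)NCCCCc3ccccc3)c2)c1` was tested in a functional assay on HOS-TE85 cells (Homo sapiens) for inhibition, read by CCK-8 assay, with a stated time of 72 h; a lower number here means a stronger inhibitor, a higher number a weaker inhibitor. In this assay compound 1 gives only a limit, > 1000 nM, not a measured number. Two related compounds fared the same way. Compound 2 `COc1ccccc1N1C(=O)CSC1c1cccc(C(=O)NCCCCn2cncn2)c1` gives > 1000 nM in this assay, again a limit. Compound 3 `O=C(NCCCCn1cccn1)c1cccc(C2SCC(=O)N2c2cccnc2)c1` gives > 1000 nM in this assay, a limit as well. All three values therefore sit at the same point, (the limit of > 1000 nM in this assay, at which 3 of the 3 values shown sit). No pair of these compounds differs in a single place, so no measured step between them is available to guide an expectation.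

Compound 4 `COc1cccc(OC)c1N1C(=O)CSC1c1cccc(C(=O)NCCCCc2ccccc2)c1` has not yet been measured. It differs from compound 1 in one place: 2,6-dimethoxyphenyl in place of 2,5-dimethoxyphenyl on an amide-type nitrogen in a ring The same atoms are present in both compounds, joined differently. With every measured value resting at a limit, the expected change is small, in no clear direction, and not beyond the usual scatter: a step that the limit leaves unreadable from compound 1 to compound 4. Compound 4 is accordingly estimated at 1500 nM in this assay, within a range from 500 nM to 5000 nM, with a fair chance that once more only a limit is reported.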

Compound 4, half-maximal inhibitory concentration: > 1000 nM
Compound 4 gave a limit, no number; the forecaster's own chance of this, stated with the estimate: 70%; the middle value does not contradict the limit.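

Among these compounds, compound 1 and compound 4 both give only a limit in this assay, so no step between them can be read, and the change from 2,5-dimethoxyphenyl to 2,6-dimethoxyphenyl has no readable size. The compounds shown leave open which change to the shared core, if any, would give a measured number rather than a limit, as every result stands at one point: the limit of > 1000 nM in this assay, at which 4 of the 4 values shown sit.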